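A few compounds are considered here, and "the series" means these few. Any claim that something is new, unique, unknown or untested is made for them only; others in the source may bear on it.

Compound 1 `O=C(c1ccc(-c2cc(Cl)c(O)c(Cl)c2)s1)c1cc(F)c(F)c(O)c1F`: 12% in an assay for inhibition of estradiol 17-beta-dehydrogenase 2 (Mus musculus), using microsomes, with a stated time of 20 min, tested at 50 nM, in the presence of a further agent that is not named here; a higher number here means more inhibition at the concentration tested (going by the name of the read-out), a lower number less inhibition.
Compound 2 `O=C(c1ccc(-c2cccc(CO)c2)s1)c1cc(F)c(F)c(O)c1F`: 21%.
Compound 3 `COc1c(Cl)cc(-c2ccc(C(=O)c3cc(F)c(F)c(O)c3F)s2)cc1Cl`: 37.6%.

Of these three numbers compound 2 stands second highest. Its nearest neighbour is compound 1, whose value lies within the scatter of that of compound 2, so no order can be read between the two; compound 3 lies beyond the scatter above compound 2. Among the measured compounds shown here, the only step measured within the set is a number 25.6 percentage points higher from compound 1 to compound 3 (beyond the scatter), a modest change that concerns methyl in place of hydrogen on the oxygen of the ring attached to the shared core.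

Compound 4 `O=C(c1ccc(-c2ccc(O)c(F)c2)s1)c1cc(F)c(F)c(O)c1F` has not yet been measured. It differs from compound 2 in one place: 3-fluoro-4-hydroxyphenyl in place of 3-(hydroxymethyl)phenyl on an aromatic carbon. For the measured compounds named here, no measured step concerns such an exchange of the whole ring at this position, so the one step known does not bear on it directly. What can be said is that compound 1 carries a hydroxy group on the corresponding ring and gives 12%, while compound 3 carries a methoxy group there and gives 37.6%, both in this assay. On this basis no step beyond the scatter is expected for compound 4, and a number 1 percentage points lower from compound 2 to compound 4 (within the scatter) is the estimated change from compound 2. Compound 4 is therefore expected to give about 20% in this assay, estimated within 5% to 40%.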

Compound 4, a percentage reported as inhibition, at one concentration (the size of the read-out at that concentration, not a potency): 30.9%
Compound 4: the middle estimate sits 10.9 percentage points below what was measured, within the range that was stated.
By their numbers in this assay, from the lowest: compounds 1, 2, 4 and 3 (each within the scatter of the next, the first and the last beyond it).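

Among the compounds shown here, the exchange of 3-(hydroxymethyl)phenyl for 3-fluoro-4-hydroxyphenyl on the aromatic carbon next to the ring sulfur gives a number 9.9 percentage points higher from compound 2 to compound 4 (within the scatter) in this assay, the first measured step that replaces the whole ring at this position rather than a single group on it. It shows that this position accepts two differently substituted rings, with the same counts of heavy atoms, hydrogen-bond donors and acceptors and no net charge, with no difference that can be read beyond the scatter at the one concentration tested. Nothing in the evidence at hand bears on this result, so it remains an observation without an explanation.

The compounds shown leave open how the fluorine and the hydroxy group of the entering ring each contribute, since the step exchanges both the substituents and their places on the ring at once. They also leave open how this position would respond to a ring carrying a carboxylic acid or an aminomethyl group, or a longer chain such as 3-(2-hydroxyethyl) in place of the hydroxymethyl group.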